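A few compounds are considered here, and "the series" means these few. Any claim that something is new, unique, unknown or untested is made for them only; others in the source may bear on it.

In a functional assay on HeLa cells (Homo sapiens) for cytotoxicity, read by MTT assay, with a stated time of 72 h (a lower number here means a stronger inhibitor, a higher number a weaker inhibitor), compound 2 `O=C(Nc1ccc(Oc2ncnc3[nH]ccc23)c(F)c1)c1cc2cccnc2n(-c2ccc(Br)cc2)c1=O` gives 19900 nM, and compound 1 `O=C(Nc1ccc(Oc2ncnc3[nH]ccc23)c(F)c1)c1cc2cccnc2n(-c2ccc(Cl)cc2)c1=O` gives 23900 nM. Among the compounds with values here, the two are level, as the only measured step shows: a 1.2-fold lower number from compound 1 to compound 2 (0.08 log units; within the scatter). Compound 3 `O=C(Nc1ccc(Oc2ncnc3[nH]ccc23)c(F)c1)c1cc2cccnc2n(-c2ccc(Br)cc2F)c1=O` carries a new change, (fluoro in place of hydrogen on an aromatic carbon), which amounts to fluoro in place of hydrogen on an aromatic carbon. Within the data shown here, no measured step covers this change, so the halogen swap a 1.2-fold lower number from compound 1 to compound 2 (0.08 log units; within the scatter) is the only guide, and no shift beyond the scatter is expected in this assay. The expected change is a 1.1-fold lower number from compound 2 to compound 3 (0.04 log units; within the scatter). For compound 3 the estimated value is 18000 nM, with an expected range of 8000 nM to 35000 nM.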

Compound 3, half-maximal inhibitory concentration: 87800 nM
Compound 3: middle estimate off by 4.9-fold (0.69 log units), on the low side; measured number outside the range, above it.
By their numbers in this assay, from the lowest: compounds 2 and 1 (each within the scatter of the next); then compound 3.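

In this assay, the change from 4-bromophenyl to 4-bromo-2-fluorophenyl gives a 4.4-fold higher number from compound 2 to compound 3 (0.64 log units; beyond the scatter), so a fluoro ortho to a large group moves this assay beyond the scatter, which the swap of bromo for chloro had not done. Set against the chloro compound, the step reads a 3.7-fold higher number from compound 1 to compound 3 (0.57 log units; beyond the scatter), in the same direction. Nothing measured here explains this shift. From the compounds shown here alone, whether a methyl group or an amine at the same place would also raise the number stays open, as does whether fluoro acts the same way alongside a chloro group.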